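The source may hold more compounds than are shown below. What is called first, only, known or untested is meant among the compounds shown, and "the series" means these compounds.

Of the compounds shown here, two from the same series have been measured. Compound 1 `CC(=O)c1ccc(N2CCN(C(=O)c3nc4ccccc4s3)CC2)cc1` and compound 2 `O=C(c1nc2cc(Cl)ccc2s1)N1CCN(c2ccccc2)CC1` share an amide-linked core, and they have been tested in an ADME assay on RAW264.7 cells (Mus musculus) for cytotoxicity, read by MTT assay, with a stated time of 72 h, tested at 50 ug/mL; a lower number here means less inhibition, a higher number more inhibition at the concentration tested (going by the name of the read-out). In this assay compound 1 gives 62.3%. Compound 2 gives 41.2%, which is the lowest of the two numbers, and the gap to compound 1 is beyond the usual scatter of this kind of measurement. Since compound 1 and compound 2 differ in more than one place, the two values are simply reported side by side here.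

Compound 3 `COc1ccc(N2CCN(C(=O)c3nc4cc(Cl)ccc4s3)CC2)cc1` has not yet been measured in this assay. It differs from compound 2 in one place: methoxy in place of hydrogen on an aromatic carbon. Among the compounds with values here, with no single-change step between measured compounds available, the expectation for this change rests only on the two values above. The expected step from compound 2 to compound 3 is a number 6.8 percentage points higher from compound 2 to compound 3 (within the scatter), which is a modest rise, of a size that might not clearly exceed the scatter. Compound 3 is therefore estimated to give 48% in this assay, within a range from 30% to 66%.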

Compound 3, a percentage reported as inhibition, at one concentration (the size of the read-out at that concentration, not a potency): 42.8%
Beside the measured number, compound 3's estimate is 5.2 percentage points above it; measured number inside the range.
By their numbers in this assay, from the lowest: compounds 2 and 3 (each within the scatter of the next); then compound 1.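

Within the data shown here, this is the first single-change comparison: methoxy in place of hydrogen on an aromatic carbon, para to a large group, gives a number 1.6 percentage points higher from compound 2 to compound 3 (within the scatter) in this assay when the rest of the molecule is held the same. At this position, on this one pair, phenyl and 4-methoxyphenyl therefore cannot be told apart by this read-out, so adding these 2 heavy atoms, including a hydrogen-bond acceptor, leaves no change that can be separated from ordinary repeat-to-repeat variation. No measurement at hand explains this result, and a single pair cannot show whether the same would hold on a different core.

The compounds shown leave open whether an amine or a carboxylic acid on this same aromatic carbon, or a longer chain such as ethoxy in place of methoxy, would give a step beyond the scatter. They also leave open whether methoxy would read the same way on another carbon of this six-membered ring.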